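Sulfonyl in place of benzyl: expectation for compound 4

The compounds below may be only part of what the source reports. "The series", "measured", "known", "first", "only" and "open" are said of these compounds alone.

Measured in an ADME assay on MT4 cells (Homo sapiens) for cytotoxicity; a lower number here means that less compound is tolerated, a higher number that more compound is tolerated:
- compound 1 `COC(=O)c1ccc(NC(=O)CSc2nc3ccccc3n2S(=O)(=O)c2cc(C)cc(C)c2)c(Cl)c1`: 145000 nM
- compound 2 `Cc1cc(C)cc(S(=O)(=O)n2c(SCC(=O)Nc3ccc(S(C)(=O)=O)cc3Cl)nc3ccccc32)c1`: > 221000 nM (a limit, not a number)
- compound 3 `Cc1cc(C)cc(Cn2c(SCC(=O)Nc3ccc(S(N)(=O)=O)cc3Cl)nc3ccccc32)c1`: 111000 nM

In this assay compound 3 gives 111000 nM and compound 1 gives 145000 nM, two values within the scatter of each other. Compound 2 is reported only as a limit, > 221000 nM.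

Compound 4 `Cc1cc(C)cc(S(=O)(=O)n2c(SCC(=O)Nc3ccc(S(N)(=O)=O)cc3Cl)nc3ccccc32)c1` has (3,5-dimethylphenyl)sulfonyl in place of 3,5-dimethylbenzyl on an aromatic nitrogen, and the rest of compound 3 is kept: (3,5-dimethylphenyl)sulfonyl in place of 3,5-dimethylbenzyl on an aromatic nitrogen.

For the measured compounds named here, no measured step covers this exchange directly. Going by the values given here, the one measured step, an at least 1.5-fold higher number from compound 1 to compound 2 (0.18 log units; that floor lies within the scatter), is methylsulfonyl in place of methoxycarbonyl on an aromatic carbon, a different place, and it rests on (the limit of > 221000 nM in this assay, at which 1 of the 3 values shown sits). Its floor lies within the scatter, so it gives no sign of a large move in this series. Compounds 1 and 2 both carry the entering group, and compound 1 sits at 145000 nM. No step beyond the scatter is therefore expected in this assay, with a small move to a higher number the likelier direction.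

The estimate is a 1.4-fold higher number from compound 3 to compound 4 (0.16 log units; within the scatter).

Compound 4 is expected at 160000 nM, with an estimated range from 85000 nM to 300000 nM.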

Compound 4, half-maximal cytotoxic concentration: 25600 nM
For compound 4 the middle estimate is 6.3-fold (0.80 log units) above the measured one; measured number outside the range, below it.
By their numbers in this assay, from the lowest: compound 4; then compounds 3 and 1 (each within the scatter of the next). At a limit, above all of these: compound 2.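

In this assay the exchange on the aromatic nitrogen is not neutral when sulfamoyl is kept (a 4.3-fold lower number from compound 3 to compound 4 (0.64 log units; beyond the scatter)), so (3,5-dimethylphenyl)sulfonyl and 3,5-dimethylbenzyl cannot be treated as interchangeable at this position. The group on the aromatic carbon also matters with the sulfonyl in place, since sulfamoyl gives a lower number than methoxycarbonyl (a 5.7-fold lower number from compound 1 to compound 4 (0.75 log units; beyond the scatter)) and amino on the sulfonyl sulfur gives a lower number than methyl (an at least 8.6-fold lower number from compound 2 to compound 4 (0.93 log units; beyond the scatter)). Among these four compounds, the clearly lower number appears only where (3,5-dimethylphenyl)sulfonyl and sulfamoyl occur together, and the step involving compound 2 gives only a floor, as compound 2 is reported as a limit: the limit of > 221000 nM in this assay, at which 1 of the 4 values shown sits.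

The compounds shown do not tell whether the sulfonyl link itself or its pairing with sulfamoyl drives this lower number, and the benzyl group is seen here only with sulfamoyl. A benzoyl group on the aromatic nitrogen, or a carboxylic acid in place of sulfamoyl on the aromatic carbon, would test how far the effect extends beyond this pair of groups.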